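From Methoxy to Butoxy in a Cytotoxicity Series

This account rests on a few compounds, and the source may have more. Where it says the series, first, only, none or still open, it means among the compounds named here.

Compound 1 `COc1ccc(C[C@H]2C(=O)OC[C@@H]2Cc2ccccc2)cc1`: 67000 nM
Compound 2 `COc1ccccc1C[C@H]1COC[C@@H]1Cc1ccc(Cl)c(Cl)c1`: 55000 nM

In a functional assay on HL-60 cells (Homo sapiens) for cytotoxicity, read by WST assay, with a stated time of 48 h (a lower number here means that less compound is needed, a higher number that more compound is needed for the effect), compound 2 gives 55000 nM, a value within the scatter of compound 1 at 67000 nM. The two compounds differ in more than one place, so they offer no measured single change to go on. Compound 3 `CCCCOc1ccccc1C[C@H]1COC[C@@H]1Cc1ccc(Cl)c(Cl)c1` has propyl in place of hydrogen on a saturated chain carbon bound to an oxygen on an aromatic ring, which turns methoxy to butoxy. Going by the values given here, with no direct precedent, a moderate move toward a lower number is expected, and the estimated step is a 2.5-fold lower number from compound 2 to compound 3 (0.40 log units; beyond the scatter). For compound 3 the estimated value is 22000 nM, with an expected range of 7000 nM to 65000 nM.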

Compound 3, half-maximal effective concentration: 20000 nM
The estimate for compound 3 lay 1.1-fold (0.04 log units) above the measured number, within the range that was stated.
By their numbers in this assay, from the lowest: compound 3; then compounds 2 and 1 (each within the scatter of the next).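

Going by these compounds alone, the change from methoxy to butoxy gives a 2.8-fold lower number from compound 2 to compound 3 (0.44 log units; beyond the scatter) in this assay and is the first single change that can be read. It shows that this saturated chain carbon bound to an oxygen on an aromatic ring takes propyl in place of hydrogen with a modest step, beyond the scatter, toward a lower number. Nothing measured here accounts for the step. Still open, on these data alone, is whether a longer chain such as hexyloxy continues this step toward a lower number, and how a chain carrying an amine or a carboxylic acid would compare.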